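The source may report more compounds than this note shows. Statements on the series, on what has been measured and on what is new or still open speak of the compounds shown alone.

In an ADME assay on HII4E cells (Mus musculus) for cytotoxicity, read by MTT assay, with a stated time of 48 h (a higher number here means a weaker inhibitor, a lower number a stronger inhibitor), compound 1 `C#CCNC(=O)CO[C@H]1O[C@H](COC(C)=O)C=C(OC(C)=O)C1=O` gives 282 ug/mL and compound 2 `C#CCNC(=O)CO[C@H]1O[C@H](COC(C)=O)C=C(OC(C)=O)/C1=C\C(=O)OCC` gives 257 ug/mL as its reading. These two numbers lie within the scatter of each other, so compound 2 stands level with compound 1 and the pair cannot be ranked. Going by the values given here, both numbers are large, and no measured compound yet stands clearly apart from the other.

The next compound is compound 3 `CCCCCCCCCCCCNC(=O)CO[C@H]1O[C@H](COC(C)=O)C=C(OC(C)=O)/C1=C\C(=O)OCC`, which keeps the rest of compound 2 and alters one place. It carries undecyl in place of ethynyl on a saturated chain carbon bound to an amide-type nitrogen. The same difference, cut one bond further out, reads propargyl to dodecyl.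

Among the compounds with values here, no measured pair shows a change of this kind, so the expectation rests on the structural change alone and remains loose. A clear step beyond the scatter is expected, toward a lower number and so toward stronger inhibition, with an estimated size of a 5.1-fold lower number from compound 2 to compound 3 (0.71 log units; beyond the scatter) in this assay as the working guess. Compound 3 is expected to read 50 ug/mL (estimated range 12 ug/mL to 200 ug/mL) when measured.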

Compound 3, half-maximal inhibitory concentration: 76 ug/mL
The estimate for compound 3 lay 1.5-fold (0.18 log units) below the measured number; low and high end bracket the measured number.
By their numbers in this assay, from the lowest: compound 3; then compounds 2 and 1 (each within the scatter of the next).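

In this assay, the step of a 3.4-fold lower number from compound 2 to compound 3 (0.53 log units; beyond the scatter) is the first difference among these compounds that lies beyond the scatter. It shows that the place on a saturated chain carbon bound to an amide-type nitrogen is one where changing the group moves the reading, here toward stronger inhibition, though the step is rated only modest and compound 3 still reads 76 ug/mL. No measurement available here explains why undecyl in place of ethynyl has this result.

Going by these compounds alone, a single pair gives only one comparison at this place, so it remains open whether the reading follows chain length, and whether a shorter chain such as hexyl, a longer chain such as hexadecyl, or a chain ending in an amine or a carboxylic acid would read differently from compound 3. Going by these compounds, it also remains open whether the same exchange of groups on the core of compound 1 would give a step of similar size.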